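A Second Nitro on Compound 1

A few compounds are considered here, and "the series" means these few. Any claim that something is new, unique, unknown or untested is made for them only; others in the source may bear on it.

In a functional assay, read by spectrophotometry, with a stated time of 1 h (a lower number here means a stronger inhibitor, a higher number a weaker inhibitor), compound 1 `O=c1[nH]c2ccccc2cc1/C=N/Nc1ccc([N+](=O)[O-])cc1` gives 245000 nM as the lowest of three measured numbers. Compound 3 `O=c1[nH]c2ccccc2cc1/C=N/Nc1ccccc1` gives 1000000 nM and compound 2 `Cc1ccc2[nH]c(=O)c(/C=N/CCO)cc2c1` gives 4180000 nM in this assay as well. Compound 4 `O=c1[nH]c2ccccc2cc1/C=N/Nc1ccc([N+](=O)[O-])cc1[N+](=O)[O-]` carries nitro in place of hydrogen on an aromatic carbon of compound 1 (nitro in place of hydrogen on an aromatic carbon). Going by the values given here, the one measured step that bears on this removes the nitro already present (a 4.1-fold higher number from compound 1 to compound 3 (0.61 log units; beyond the scatter)) and is modest but beyond the scatter. Among the compounds with values here, compound 2 supplies no such step. A second nitro is therefore expected to bring a modest fall in this assay and perhaps none beyond the scatter, and one step is thin ground. The expected change is modest (a 2.0-fold lower number from compound 1 to compound 4 (0.31 log units; beyond the scatter)). For compound 4 the estimate is 120000 nM with an expected range from 40000 nM to 350000 nM overall.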

Compound 4, half-maximal inhibitory concentration: 375000 nM
Beside the measured number, compound 4's estimate is 3.1-fold (0.49 log units) below it, and the stated range ends below it.
By their numbers in this assay, from the lowest: compounds 1 and 4 (each within the scatter of the next); then compound 3; then compound 2.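

In this assay the nitro added ortho to a large group and meta to a nitro group gives a 1.5-fold higher number from compound 1 to compound 4 (0.18 log units; within the scatter) and so stays within the scatter. The position therefore takes this second nitro with no change that can be told from the scatter, whereas the earlier step of a 4.1-fold higher number from compound 1 to compound 3 (0.61 log units; beyond the scatter) lies beyond it. No measurement at hand gives a reason for this result. From the compounds shown here alone, whether an amine or a carboxylic acid at this position would move the number beyond the scatter remains open.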